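A few compounds are considered here, and "the series" means these few. Any claim that something is new, unique, unknown or untested is made for them only; others in the source may bear on it.

Compound 3 `O=S(=O)(c1ccc(-c2ccc3ncnc(Nc4ccc(OCc5cccc(F)c5F)c(Cl)c4)c3c2)cc1)N1CCOCC1` was examined in an ADME assay on HepG2 cells (Homo sapiens) for cytotoxicity, read by MTT assay, with a stated time of 48 h (a higher number here means a weaker inhibitor, a lower number a stronger inhibitor), and gave only a limit, > 15000 nM. Compound 1 `Cc1ccc(Nc2ncnc3ccc(-c4ccc(S(=O)(=O)N5CCOCC5)cc4)cc23)cc1` likewise returned only the limit > 15000 nM. Compound 2 `COc1ccc(Nc2ncnc3ccc(-c4ccc(S(=O)(=O)N5CCOCC5)cc4)cc23)cc1Cl` also returned only the limit > 15000 nM. Within the data shown here, all three values therefore sit at the same boundary, as the one piece of evidence records: the limit of > 15000 nM in this assay, at which 3 of the 3 values shown sit. The step that the two limits leave unreadable from compound 1 to compound 2 and the step that the two limits leave unreadable from compound 2 to compound 3 are both of unreadable size and direction for that reason, and compound 3 stands with the other two at the limit of this assay rather than at a number.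

The unmeasured compound 4 `O=S(=O)(c1ccc(-c2ccc3ncnc(Nc4ccc(OCc5cc(F)cc(F)c5F)c(Cl)c4)c3c2)cc1)N1CCOCC1` differs from compound 3 in one place: fluoro in place of hydrogen on an aromatic carbon. Cut one bond further out, the same difference reads 2,3-difluorophenyl to 2,3,5-trifluorophenyl, or (2,3-difluorobenzyl)oxy to (2,3,5-trifluorobenzyl)oxy.

Among the measured compounds shown here, neither measured step offers a readable size to carry over, so no direction can be drawn from them; what can be said is that every compound so far has rested at the limit. Compound 4 is accordingly expected to give 20000 nM, in a range from 10000 nM to 60000 nM, most probably reported again as a limit. The estimated step is a step that the limit leaves unreadable from compound 3 to compound 4, which is expected to be no more than the scatter.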

Compound 4, half-maximal inhibitory concentration: > 3000 nM
Compound 4 gave a limit, no number; the forecaster's own chance of this, stated with the estimate: 85%; the middle value lies beyond the limit too.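

In this assay compound 4 gave only a limit, > 3000 nM. Compared with compound 2 and compound 3, which also rest at limits, compound 4 yields no step that can be read. The compounds shown leave open what concentration of any of these four would actually reach half-maximal inhibition, and whether the added fluoro changes it.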